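A few compounds are considered here, and "the series" means these few. Any claim that something is new, unique, unknown or untested is made for them only; others in the source may bear on it.

Three compounds share one core. Compound 1 `COc1cc(-c2nnc(SCC(=O)c3ccc(C(F)(F)F)cc3)n2N)cc(OC)c1OC` carries a 4-(trifluoromethyl)phenyl group on the carbonyl carbon. In a functional assay on PC-3 cells (Homo sapiens) for antiproliferative activity, read by MTT assay, with a stated time of 48 h (on this read-out lower numbers stand for stronger inhibition and higher numbers for weaker inhibition), compound 1 gives only a limit of the assay, > 100000 nM, and not a number. Compound 2 `COc1cc(-c2nnc(SCC(=O)c3ccc(F)cc3)n2N)cc(OC)c1OC` carries a 4-fluorophenyl group at the same place. In this assay compound 2 likewise gives only a limit, > 100000 nM. Compound 3 `COc1cc(-c2nnc(SCC(=O)Nc3ccccc3C)n2N)cc(OC)c1OC` carries a (2-methylphenyl)amino group there. In this assay compound 3 gives only a limit as well, > 100000 nM. The steps a step that the two limits leave unreadable from compound 1 to compound 2, a step that the two limits leave unreadable from compound 1 to compound 3 and a step that the two limits leave unreadable from compound 2 to compound 3 therefore cannot be read in size, since all three values sit at the limit of > 100000 nM in this assay, at which 3 of the 3 values shown sit.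

Compound 4 `COc1cc(-c2nnc(SCC(=O)NCc3ccc(Cl)cc3)n2N)cc(OC)c1OC` is not yet measured. It differs from compound 2 by (4-chlorobenzyl)amino in place of 4-fluorophenyl on a carbonyl carbon. Within the data shown here, no measured step gives a readable size for this kind of change, and compound 3, which also carries an amino group on the carbonyl carbon, sits at the limit. So compound 4 is expected to show no step beyond the scatter, a number no higher from compound 2 to compound 4 (the limit leaves the size open), in this assay. For compound 4 the estimate is 100000 nM, within 30000 nM to 300000 nM.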

Compound 4, half-maximal inhibitory concentration: > 100000 nM
Compound 4 gave a limit, no number; the forecaster's own chance of this, stated with the estimate: 80%; the middle value sits exactly at the limit.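

Compound 4 gives only a limit in this assay, so none of the steps linking it to compound 1, compound 2 or compound 3 can be read in size: the limit of > 100000 nM in this assay, at which 4 of the 4 values shown sit. The compounds shown leave open which group on the carbonyl carbon, if any, would give a readable number in this assay and how large any difference between such groups would be.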